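Solubility notes: dimethoxyphenyl replacing chlorophenyl in compound 4

A few compounds are considered here, and "the series" means these few. Any claim that something is new, unique, unknown or untested is made for them only; others in the source may bear on it.

Compound 1 `Cc1oc(-c2ccc(Cl)cc2)nc1CN1CCC(C(=O)NCCCN2C[C@H](C)C[C@H](C)C2)CC1` is the reference point. In a physicochemical assay for solubility, in phosphate buffer, measured as kinetic solubility, at pH 7.4 (on this read-out higher numbers stand for higher solubility and lower numbers for lower solubility), compound 1 gives > 72 ug/mL, which is a limit of the assay and not a number. Compound 2 `Cc1ccccc1-c1nc(CN2CCC(C(=O)NCCCN3[C@H](C)CCC[C@@H]3C)CC2)c(C)o1` also returns only a limit in this assay, > 69 ug/mL. Compound 3 `CCCN(CCC)CCNC(=O)C1CCN(Cc2nc(-c3ccccc3C)oc2C)CC1` likewise returns a limit in this assay, > 65 ug/mL. Within the data shown here, the single measured step, a step that the two limits leave unreadable from compound 2 to compound 3, therefore cannot be read; the three results together show only that every compound so far sits at a limit, whether (the limit of > 65 ug/mL in this assay, at which 1 of the 3 values shown sits), the limit of > 69 ug/mL in this assay, at which 1 of the 3 values shown sits, or (the limit of > 72 ug/mL in this assay, at which 1 of the 3 values shown sits).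

Compound 4 `COc1ccc(-c2nc(CN3CCC(C(=O)NCCCN4C[C@H](C)C[C@H](C)C4)CC3)c(C)o2)cc1OC` differs from compound 1 by 3,4-dimethoxyphenyl in place of 4-chlorophenyl on an aromatic carbon. Among the measured compounds shown here, no measured step touches this part of the core of compound 1, so there is no measured size to carry over. Because compound 1 sits at the limit of > 72 ug/mL in this assay, at which 1 of the 3 values shown sits, the expected step that the limit leaves unreadable from compound 1 to compound 4 is set at no change beyond the scatter. Compound 4 is estimated to give about 80 ug/mL in this assay, within a range from 40 ug/mL to 160 ug/mL, and most likely to be reported again as a limit.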

Compound 4, solubility: > 76 ug/mL
Compound 4 ended at the assay's limit; the forecaster's own chance of this, stated with the estimate: 70%; the middle value lies beyond the limit too.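

In this assay compound 4 gives > 76 ug/mL, a limit of the assay and not a number. Compound 1 also sits at a limit, so the step between compound 1 and compound 4 cannot be read. Open, as far as these compounds go, is whether 3,4-dimethoxyphenyl in place of 4-chlorophenyl shifts solubility at all.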